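The compounds below may be only part of what the source reports. "The series", "measured", "known", "first", "only" and "open" are said of these compounds alone.

Measured so far in an assay on SK-BR-3 cells for inhibition of Aromatase (Homo sapiens); on this read-out higher numbers stand for weaker inhibition and lower numbers for stronger inhibition:
Compound 1, `CCCOc1cc([N+](=O)[O-])ccc1NS(C)(=O)=O`, gives 2510 nM.
Compound 2, `CC(C)Oc1cc([N+](=O)[O-])ccc1NS(C)(=O)=O`, gives 5870 nM.
Compound 3, `CS(=O)(=O)Nc1ccc([N+](=O)[O-])cc1OC1CCCC1`, gives 870 nM.

Compound 3 stands lowest of the three numbers in this assay; compound 1 is nearest to it and compound 2 furthest, both steps beyond the scatter.

Compound 4, `CCC(CC)Oc1cc([N+](=O)[O-])ccc1NS(C)(=O)=O`, differs from compound 3 by pentan-3-yl in place of cyclopentyl on an oxygen on an aromatic ring. Two kinds of measured step bear on this. Closing the chain into a ring on the oxygen lowered the number each time: a 2.9-fold lower number from compound 1 to compound 3 (0.46 log units; beyond the scatter) and a 6.7-fold lower number from compound 2 to compound 3 (0.83 log units; beyond the scatter). Branching the open chain raised it: a 2.3-fold higher number from compound 1 to compound 2 (0.37 log units; beyond the scatter). Compound 4 opens the ring again and carries a branched chain, so the move is expected to run back toward compound 2, upward in this assay, by a modest step beyond the scatter, roughly the reverse of the ring-closing steps.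

For compound 4 the step is expected to be a 4.0-fold higher number from compound 3 to compound 4 (0.60 log units; beyond the scatter). Compound 4 is therefore estimated at 3500 nM in this assay, within a range from 1200 nM to 9000 nM.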

Compound 4, half-maximal inhibitory concentration: 300 nM
The estimate for compound 4 lay 12-fold (1.07 log units) above the measured number; measured number outside the range, below it.
By their numbers in this assay, from the lowest: compound 4; then compound 3; then compound 1; then compound 2.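

In this assay, pentan-3-yl in place of cyclopentyl on the oxygen gives a 2.9-fold lower number from compound 3 to compound 4 (0.46 log units; beyond the scatter) and so shows that a closed ring is not required for a low number at this position. Branching alone does not set the direction either: pentan-3-yl in place of isopropyl gives a 20-fold lower number from compound 2 to compound 4 (1.29 log units; beyond the scatter) even though both groups are branched, and ethyl in place of hydrogen on the chain carbon bound to the oxygen gives an 8.4-fold lower number from compound 1 to compound 4 (0.92 log units; beyond the scatter) as a further drop. Nothing on hand accounts for these steps.

Open, going by these compounds, is whether the number keeps falling with a larger branched group such as heptan-4-yl or with a larger ring such as cyclohexyl. Also open, on these data alone, is how an amine or a hydroxyl group on the pentan-3-yl chain would read.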